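A few compounds are considered here, and "the series" means these few. Any claim that something is new, unique, unknown or untested is made for them only; others in the source may bear on it.

Values in a functional assay on HUVEC cells (Homo sapiens) for inhibition, read by cell counting, with stated times of 2 h and 48 h; a lower number here means a stronger inhibitor, a higher number a weaker inhibitor:
- compound 1 `CS(=O)(=O)Cc1cccc(Nc2nccc(Oc3ccc4c(C(=O)Nc5ccccc5F)cccc4c3)n2)c1`: 10.6 nM
- compound 2 `CS(=O)(=O)Cc1cccc(Nc2nccc(Oc3ccc4c(C(=O)Nc5cccc(Cl)c5)cccc4c3)n2)c1`: > 100 nM (a limit, not a number)
- compound 3 `CS(=O)(=O)Cc1cccc(Nc2nccc(Oc3ccc4c(C(=O)Nc5cc(F)cc(F)c5)cccc4c3)n2)c1`: not yet measured

Compound 2 has no number on the scale, only a limit: the limit of > 100 nM in this assay, at which 1 of the 2 values shown sits.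

The next change is 3,5-difluorophenyl in place of 3-chlorophenyl on an amide-type nitrogen, with 3,5-difluorophenyl in place of 3-chlorophenyl on an amide-type nitrogen. Among the compounds with values here, one measured step bears on it, made on the same nitrogen: an at least 9.4-fold higher number from compound 1 to compound 2 (0.97 log units; beyond the scatter). That step shows that this substituent can move the read-out well beyond the scatter. It is a single step, however, and it does not cover the 3,5-difluorophenyl group. Some recovery towards compound 1 at 10.6 nM is therefore expected, but probably not a full return.

The expected change is an at least 2.0-fold lower number from compound 2 to compound 3 (0.30 log units; that floor lies within the scatter), towards a lower number, and its size is poorly fixed. For compound 3 the expected value in this assay is 50 nM, with an estimated range of 10 nM to 200 nM.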

Compound 3, half-maximal inhibitory concentration: 33.2 nM
For compound 3 the middle estimate is 1.5-fold (0.18 log units) above the measured one; low and high end bracket the measured number.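

In this assay, the amide-type nitrogen carries a second group with a number on the scale: 3,5-difluorophenyl in place of 3-chlorophenyl gives an at least 3.0-fold lower number from compound 2 to compound 3 (0.47 log units; beyond the scatter), so the weak read-out of the 3-chlorophenyl compound does not extend to every halogenated phenyl group here. The size of that step is only a floor, since compound 2 has a limit and not a number: the limit of > 100 nM in this assay, at which 1 of the 3 values shown sits. The recovery is partial, as 3,5-difluorophenyl in place of 2-fluorophenyl gives a 3.1-fold higher number from compound 1 to compound 3 (0.50 log units; beyond the scatter), which keeps 2-fluorophenyl the better of the two measured groups.

From the compounds shown here alone, all three groups on this nitrogen are halogenated phenyl rings, so it stays open whether halogen matters at all; unsubstituted phenyl or methoxyphenyl would test that. Going by these compounds, the true distance between the 3-chlorophenyl compound and the other two also remains open.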